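A few compounds are considered here, and "the series" means these few. Any claim that something is new, unique, unknown or untested is made for them only; others in the source may bear on it.

Measured so far in a functional assay on SNB-19 cells (Homo sapiens) for inhibition, read by sulforhodamine B assay, with a stated time of 48 h; on this read-out lower numbers stand for stronger inhibition of growth and higher numbers for weaker inhibition of growth:
compound 1 `Nc1cc(N)c2nc(-c3ccccc3)c(NCc3ccc(Cl)c(Cl)c3)nc2c1` gives 22400 nM
compound 2 `Nc1cc(N)c2nc(-c3ccccc3)c(Sc3ccc(F)cc3)nc2c1` gives 20000 nM
compound 3 `COc1cc(CNc2nc3cc(N)cc(N)c3nc2-c2ccccc2)cc(OC)c1OC` gives 7240 nM

All three share one core. Among these numbers compound 2 stands second highest; compound 1 lies within the usual scatter of it, whereas compound 3 sits beyond the scatter with the lower number of the pair. Compound 4 `Nc1cc(N)c2nc(-c3ccccc3)c(Sc3ccc(Cl)c(Cl)c3)nc2c1` has not yet been measured. It differs from compound 2 in one place: 3,4-dichlorophenyl in place of 4-fluorophenyl on a sulfur. Within the data shown here, no pair of measured compounds isolates this change, so its effect in this assay cannot be read off; a step of no more than the usual scatter, in no firm direction, is expected. Compound 4 is therefore expected near 18000 nM, in a range from 7000 nM to 45000 nM. The expected step is a 1.1-fold lower number from compound 2 to compound 4 (0.05 log units; within the scatter).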

Compound 4, concentration for 50% growth inhibition: 17000 nM
Compound 4: the middle estimate sits 1.1-fold (0.02 log units) above what was measured; the range from low to high includes it.
By their numbers in this assay, from the lowest: compound 3; then compounds 4, 2 and 1 (each within the scatter of the next).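

In this assay, putting 3,4-dichlorophenyl in place of 4-fluorophenyl on a sulfur gives a 1.2-fold lower number from compound 2 to compound 4 (0.07 log units; within the scatter) and so the two compounds cannot be told apart. Among these compounds, this is the first pair that isolates one change at this position, and it shows that two chlorines in place of one fluorine leave the growth-inhibition number within the usual scatter. Nothing available here explains why the two compounds match.

On these data alone, whether a carboxylic acid, an amine or a longer chain on the sulfur would shift the number remains open.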